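The source may report more compounds than this note shows. Statements on the series, on what has been measured and on what is new or still open speak of the compounds shown alone.

Working notes on the series. In an assay on cells for agonist activity at probable G-protein coupled receptor 34 (Mus musculus), with a stated time of 1 h (a lower number here means a smaller maximal response, a higher number a larger maximal response), compound 1 `N[C@@H](COP(=O)(O)OCCCOC(=O)CCc1ccccc1OCc1cccc(Oc2cccc(Cl)c2)c1)C(=O)O` gives 17.1%, compound 2 `N[C@@H](COP(=O)(O)OCCCOC(=O)CCc1ccccc1OCc1cccc(Oc2ccc(Cl)cc2)c1)C(=O)O` gives 17.8%, and compound 3 `CCc1ccc(Oc2cccc(COc3ccccc3CCC(=O)OCCCOP(=O)(O)OC[C@H](N)C(=O)O)c2)cc1` gives 19.3%. Compound 3 carries the highest of the three numbers, yet every gap lies within the scatter: a number 0.7 percentage points higher from compound 1 to compound 2 (within the scatter), a number 2.2 percentage points higher from compound 1 to compound 3 (within the scatter), a number 1.5 percentage points higher from compound 2 to compound 3 (within the scatter). Compound 4 `N#Cc1ccc(Oc2cccc(COc3ccccc3CCC(=O)OCCCOP(=O)(O)OC[C@H](N)C(=O)O)c2)cc1` differs from compound 3 by cyano in place of ethyl on an aromatic carbon. For the measured compounds named here, the only measured step that bears on an exchange at this aromatic carbon is a number 1.5 percentage points higher from compound 2 to compound 3 (within the scatter), itself within the scatter; no measured step involves a cyano group, so the data give no direction for it. The expected step is accordingly a number 1.3 percentage points lower from compound 3 to compound 4 (within the scatter), nothing beyond the scatter. Compound 4 is estimated at 18%, with a range from 10% to 27%.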

Compound 4, largest response reached (Emax), in percent of the reference or control that the assay uses: 18.3%
Compound 4: the middle estimate sits 0.3 percentage points below what was measured, within the range that was stated.
By their numbers in this assay, from the lowest: compounds 1, 2, 4 and 3 (each within the scatter of the next).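

At this aromatic carbon, para to a large group, cyano in place of ethyl gives a number 1 percentage points lower from compound 3 to compound 4 (within the scatter), and cyano in place of chloro gives a number 0.5 percentage points higher from compound 2 to compound 4 (within the scatter). The wider exchange of 3-chlorophenyl for 4-cyanophenyl gives a number 1.2 percentage points higher from compound 1 to compound 4 (within the scatter), so the entering nitrile, with its hydrogen-bond acceptor, leaves the maximal response within the scatter of all three earlier compounds. No supporting information bears on this result. As far as these compounds go, whether an amine, a carboxylic acid or a longer chain at this carbon would move the response beyond the scatter remains open.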